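Trifluoromethyl on the core of compound 2

This account rests on a few compounds, and the source may have more. Where it says the series, first, only, none or still open, it means among the compounds named here.

In a functional assay on A549 cells (Homo sapiens) for inhibition, read by CCK-8 assay, with a stated time of 72 h (on this read-out lower numbers stand for stronger inhibition and higher numbers for weaker inhibition), compound 2 `Fc1ccc(CNc2nc(Nc3cc(C4CC4)[nH]n3)c3ccccc3n2)c(F)c1` gives 1700 nM, the lowest of the two numbers in the series. Compound 1 `Cc1cc(Nc2nc(NCc3cc(F)ccc3F)nc3ccccc23)n[nH]1` gives 6800 nM. The gap between these two compounds lies beyond the scatter. Compound 3 `Cc1cc(Nc2nc(NCc3ccc(F)cc3F)nc3cc(Cl)ccc23)n[nH]1` gives > 100000 nM, which is a limit of this assay and not a number. Compound 4 `Fc1ccc(CNc2nc(Nc3cc(C4CC4)[nH]n3)c3ccc(C(F)(F)F)cc3n2)c(F)c1` follows from compound 2 with trifluoromethyl in place of hydrogen on an aromatic carbon. Among the compounds with values here, no measured pair isolates a change on the core. Within the data shown here, compound 3, with its limit of > 100000 nM, is the only measured compound with a substituted core, so weaker inhibition is expected in this assay. The expected step, beyond the scatter, is a 5.9-fold higher number from compound 2 to compound 4 (0.77 log units; beyond the scatter). The estimated value for compound 4 is 10000 nM, within an expected range of 2000 nM to 60000 nM.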

Compound 4, half-maximal inhibitory concentration: 19000 nM
Compound 4: middle estimate off by 1.9-fold (0.28 log units), on the low side; measured number inside the range.
By their numbers in this assay, from the lowest: compound 2; then compound 1; then compound 4. At a limit, above all of these: compound 3.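

Trifluoromethyl in place of hydrogen on an aromatic carbon gives the first step on the shared core that isolates one change in this assay: an 11-fold higher number from compound 2 to compound 4 (1.05 log units; beyond the scatter). This change weakens inhibition, yet compound 4 still gives a number, 19000 nM. Compound 3, the other compound with a substituted core, gives a limit and not a number: the limit of > 100000 nM in this assay, at which 1 of the 4 values shown sits.

From the compounds shown here alone, whether a methoxy group or an amine on this aromatic carbon would weaken inhibition as trifluoromethyl does stays open. Going by these compounds, the effect of trifluoromethyl on the other carbons of this ring also stays open.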